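This account rests on a few compounds, and the source may have more. Where it says the series, first, only, none or still open, it means among the compounds named here.

In an ADME assay on L6 cells (Rattus norvegicus) for cytotoxicity, read by resazurin assay, with a stated time of 72 h (a lower number here means that less compound is needed, a higher number that more compound is needed for the effect), three measured compounds sit close together. Compound 3 `CC1=CC(=O)/C(=C\c2cc(C)n(-c3ccccc3C(F)(F)F)c2C)N1` gives 54000 nM, compound 1 `CCOC(=O)C1=C(C)N/C(=C/c2cc(C)n(-c3ccc(SC)cc3)c2C)C1=O` gives 54000 nM, and compound 2 `CCOC(=O)C1=C(C)N/C(=C/c2ccn(-c3ccccc3C(F)(F)F)c2)C1=O` gives 47000 nM; all three differ from one another only within the scatter of this assay, so none can be set apart from the others on these numbers.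

Compound 4 `CC1=C(C(=O)N2CCCCC2)C(=O)/C(=C\c2cc(C)n(-c3ccccc3C(F)(F)F)c2C)N1` has not yet been measured. It differs from compound 3 by (piperidin-1-yl)carbonyl in place of hydrogen on a double-bonded ring carbon. Among the measured compounds shown here, no pair of measured compounds shows what such an addition does in this assay, and the three compounds measured so far, which vary in their aryl substituents and in the ester, all land in the same narrow band. On that basis the step of a 1.2-fold lower number from compound 3 to compound 4 (0.08 log units; within the scatter) is expected to be small, with no direction that can be stated beyond the scatter. Compound 4 is therefore estimated at 45000 nM, with a plausible range from 20000 nM to 100000 nM.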

Compound 4, half-maximal effective concentration: 26000 nM
Compound 4: middle estimate off by 1.7-fold (0.24 log units), on the high side; measured number inside the range.
By their numbers in this assay, from the lowest: compounds 4, 2, 1 and 3 (each within the scatter of the next, the first and the last beyond it).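

In this assay, among the compounds shown here, the step of a 2.1-fold lower number from compound 3 to compound 4 (0.32 log units; beyond the scatter) is the first change in one place that can be read, and it lies beyond the scatter, though only modestly. For the compounds shown here, it shows that this double-bonded ring carbon, two ring bonds from the ring nitrogen, is not a silent position: adding (piperidin-1-yl)carbonyl in place of hydrogen moves the number down, whereas the earlier compounds could show no effect of any single change. Nothing at hand gives a reason for this shift.

Going by these compounds alone, whether the shift follows the carbonyl or the piperidine ring stays open, since no compound here carries a carboxylic acid or a morpholine amide on this carbon. Compounds 1 and 2 differ from compound 4 in more than one place, so they cannot settle this.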